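This account rests on a few compounds, and the source may have more. Where it says the series, first, only, none or still open, it means among the compounds named here.

Measured so far in an assay on RPMI-8226 cells for antagonist activity at P2X purinoceptor 7 (Homo sapiens), read by calcium flux; on this read-out higher numbers stand for weaker inhibition and lower numbers for stronger inhibition:
- compound 1 `O=c1[nH]c2ccccc2n1CCCCN1CCN(C(c2ccccc2)c2ccccc2)CC1`: 180 nM
- compound 2 `O=c1[nH]c2ccccc2n1CCCCCN1CCN(C(c2ccccc2)c2ccccc2)CC1`: 560 nM
- compound 3 `Cc1cccc2c1ccn2CCCCN1CCN(C(c2ccccc2)c2ccccc2)CC1`: 5300 nM

Compound 2 stands second highest of the three numbers: compound 1 is its nearest neighbour, a 3.1-fold higher number from compound 1 to compound 2 (0.49 log units; beyond the scatter), and compound 3 its furthest, a 9.5-fold higher number from compound 2 to compound 3 (0.98 log units; beyond the scatter).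

Compound 4 `Fc1cc2ccn(CCCCN3CCN(C(c4ccccc4)c4ccccc4)CC3)c2cc1F` is not yet measured. Relative to compound 2 the change is a group of 11 heavy atoms (8 carbon, 1 nitrogen, 2 fluorine; one five-membered aromatic ring with 1 hetero atom, one six-membered aromatic ring of carbon only) in place of a group of 11 heavy atoms (8 carbon, 2 nitrogen, 1 oxygen; one five-membered aromatic ring with 2 hetero atoms, one six-membered aromatic ring of carbon only), on a saturated chain carbon, four bonds along the chain from an amine nitrogen in a ring.

Within the data shown here, two measured steps bear on it. The step to compound 3 replaces the same leaving group with a group of 10 heavy atoms, one five-membered aromatic ring with 1 hetero atom and one six-membered aromatic ring of carbon only, at the same place: a 9.5-fold higher number from compound 2 to compound 3 (0.98 log units; beyond the scatter). From compound 1 the parallel step is a 29-fold higher number from compound 1 to compound 3 (1.47 log units; beyond the scatter). Both point to a clearly higher number once the five-membered aromatic ring with 2 hetero atoms and its hydrogen-bond donor are gone. Nothing measured separates the two fluorine atoms from the methyl carbon of compound 3, so compound 4 is expected to land near compound 3, with a step from compound 2 of a 7.1-fold higher number from compound 2 to compound 4 (0.85 log units; beyond the scatter). Compound 4 is therefore estimated at 4000 nM, within 1500 nM to 12000 nM.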

Compound 4, half-maximal inhibitory concentration: 130 nM
Compound 4: the middle estimate sits 31-fold (1.49 log units) above what was measured; measured number below the stated range.
By their numbers in this assay, from the lowest: compounds 4 and 1 (each within the scatter of the next); then compound 2; then compound 3.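

In this assay, the group at this place, on a saturated chain carbon, four bonds along the chain from an amine nitrogen in a ring, does not need a five-membered aromatic ring with 2 hetero atoms or a hydrogen-bond donor: the entering group has 1 hetero atom in that ring and 0 hydrogen-bond donors, yet gives a 4.3-fold lower number from compound 2 to compound 4 (0.63 log units; beyond the scatter) and stays level with the group of compound 1, a 1.4-fold lower number from compound 1 to compound 4 (0.14 log units; within the scatter). The weak value of compound 3 therefore cannot be assigned to this ring type as such, since two groups of that type differ widely, a 41-fold lower number from compound 3 to compound 4 (1.61 log units; beyond the scatter). No measurement given here explains these differences.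

As far as these compounds go, it remains open whether chlorine in place of the fluorine atoms would hold this level. Also open, from the compounds shown here alone, is whether a longer chain would cost as much with the fluorine-bearing group as a 3.1-fold higher number from compound 1 to compound 2 (0.49 log units; beyond the scatter).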